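The source may hold more compounds than are shown below. What is called first, only, known or untested is meant among the compounds shown, and "the series" means these compounds.

Compound 1 `Cc1cccc(NC(=O)N[C@H](C)c2ccccc2)c1` is the lowest of the three measured compounds in an ADME assay on the whole organism with Oryza sativa as the target, tested at 10 uM (on this read-out higher numbers stand for a weaker effect at the one concentration tested and lower numbers for a stronger effect), where compound 1 gives 47%. Its enantiomer compound 2 `Cc1cccc(NC(=O)N[C@@H](C)c2ccccc2)c1` gives 100%, and compound 3 `C[C@H](NC(=O)Nc1ccc(C(C)(C)C)cc1)c1ccccc1` gives 64%. Among the compounds with values here, the one single-point step measured, a number 53 percentage points higher from compound 1 to compound 2 (beyond the scatter), rests on the fact that compounds 1 and 2 differ only in the configuration as drawn and says nothing about substituents on the aromatic ring. Compound 4 `COc1cccc(NC(=O)N[C@H](C)c2ccccc2)c1` differs from compound 1 by methoxy in place of methyl on an aromatic carbon. Within the data shown here, no measured step bears on this change, so no step beyond the scatter is expected; compound 4 is estimated to stay near compound 1, a move of a number 3 percentage points higher from compound 1 to compound 4 (within the scatter). The expected value for compound 4 in this assay is 50%, in the range 25% to 80%.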

Compound 4, a percentage reported as activity, at one concentration (the size of the read-out at that concentration, not a potency): 70%
Compound 4: middle estimate off by 20 percentage points, on the low side; measured number inside the range.
By their numbers in this assay, from the lowest: compound 1; then compounds 3 and 4 (each within the scatter of the next); then compound 2.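

In this assay, the aromatic carbon that carries methyl in compound 1 proves sensitive to substitution: methoxy there gives a number 23 percentage points higher from compound 1 to compound 4 (beyond the scatter), which on this read-out means a weaker effect. This is the first step shown that changes a ring substituent rather than configuration, so the read-out responds to this position as well as to the stereocentre. Nothing available accounts for this step.

From the compounds shown here alone, it remains open whether chlorine, hydroxyl or an amine on this carbon would read closer to compound 1 or to compound 4. Going by these compounds, it is also open whether the methoxy compound of opposite configuration would show a step like that between the two methyl enantiomers.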